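Thiazole for thiophene on the amide-side methylene

The compounds below may be only part of what the source reports. "The series", "measured", "known", "first", "only" and "open" are said of these compounds alone.

Of the compounds shown here, three have been measured in an assay on HEK293 cells for agonist activity at transient receptor potential cation channel subfamily M member 8 (Homo sapiens), read by fluorescence and calcium flux, with a stated time of 15 min; a lower number here means that less compound is needed, a higher number that more compound is needed for the effect. Compound 1 `CCN(Cc1cccs1)C(=O)COc1ccc(C)cc1` gives 8 nM, compound 2 `CCN(Cc1c[nH]nn1)C(=O)COc1ccc(C)cc1` gives 31100 nM, and compound 3 `CCN(Cc1ccsc1)C(=O)COc1ccc(C)cc1` gives 88 nM. Compound 3 therefore stands second of the three numbers, with an 11-fold higher number from compound 1 to compound 3 (1.04 log units; beyond the scatter) on one side and a 350-fold lower number from compound 2 to compound 3 (2.55 log units; beyond the scatter) on the other.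

Compound 4 `CCN(Cc1nccs1)C(=O)COc1ccc(C)cc1` differs from compound 3 by 1,3-thiazol-2-yl in place of thiophen-3-yl on a saturated chain carbon bound to an amide-type nitrogen. Among the measured compounds shown here, two measured steps bear on this change. The step of an 11-fold higher number from compound 1 to compound 3 (1.04 log units; beyond the scatter) shows that the point of attachment of the thiophene matters, and the thiazol-2-yl group returns to the attachment pattern of compound 1. The step of a 3900-fold higher number from compound 1 to compound 2 (3.59 log units; beyond the scatter) shows that an azole with more ring heteroatoms costs a great deal, and the thiazole carries one more ring heteroatom than either thiophene. Weighing these, a moderate rise in the number is expected, a 5.7-fold higher number from compound 3 to compound 4 (0.75 log units; beyond the scatter), since the second effect outweighs the first in the data. Compound 4 is estimated at 500 nM, within a range from 50 nM to 5000 nM.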

Compound 4, half-maximal effective concentration: 3060 nM
Estimate against measurement, compound 4: 6.1-fold (0.79 log units) below; the range from low to high includes it.
By their numbers in this assay, from the lowest: compound 1; then compound 3; then compound 4; then compound 2.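

In (this assay) the 1,3-thiazol-2-yl group does not keep the standing of thiophen-2-yl, whose attachment pattern it shares (a 380-fold higher number from compound 1 to compound 4 (2.58 log units; beyond the scatter)), so on this saturated chain carbon bound to an amide-type nitrogen the added ring nitrogen outweighs the point of attachment. The thiazole also lies well above thiophen-3-yl (a 35-fold higher number from compound 3 to compound 4 (1.54 log units; beyond the scatter)) yet stays clear of the 1H-1,2,3-triazol-4-yl group (a 10-fold lower number from compound 2 to compound 4 (1.01 log units; beyond the scatter)), which places it between the thiophenes and the triazole on this scale. Nothing at hand accounts for the size of these steps.

The compounds shown leave open whether the change follows the ring nitrogen itself or its place in the ring, which a 1,3-thiazol-4-yl or 1,3-thiazol-5-yl group would separate. They also leave open how a phenyl or furan-2-yl group would fare here.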